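The source may report more compounds than this note shows. Statements on the series, on what has been measured and on what is new or still open speak of the compounds shown alone.

Measured compounds:
Compound 1 `COc1nc(C)c(CCO)c(OC)n1`: > 100000 nM
Compound 2 `COc1nc(Cl)nc(C)c1CCO`: "not determined" (no result reported)
Compound 3 `COc1ccc(C(OCCc2c(C)nc(OC)nc2OC)(c2ccccc2)c2ccccc2)cc1`: 5000 nM

In a functional assay on MOLT-4 cells (Homo sapiens) for antiproliferative activity, read by MTT assay, with a stated time of 24 h (a lower number here means a stronger inhibitor, a higher number a weaker inhibitor), compound 1 reaches only a limit, > 100000 nM, and that limit is the limit of > 100000 nM in this assay, at which 1 of the 3 values shown sits. In this assay compound 3 gives 5000 nM. On these data alone, for compound 2 the result is "not determined" (no result reported), so compound 2 stands at no point on this scale and the bracket it belongs in is unknown. Compound 4 `COc1nc(Cl)nc(C)c1CCOC(C)=O` differs from compound 2 by acetyl in place of hydrogen on an oxygen on a saturated carbon. For the measured compounds named here, no pair of measured compounds shows what such a change does in this assay, so the expected shift is small and of no fixed direction, within the scatter. Compound 4 is therefore estimated at 40000 nM, in a wide range from 5000 nM to 100000 nM.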

Compound 4, half-maximal inhibitory concentration: > 100000 nM
Compound 4: a limit, no number (the forecaster's own chance of this, stated with the estimate: 50%); at least 2.5-fold (0.39 log units) between middle value and limit.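

No step can be read from compound 2 to compound 4: compound 2 has no result. Compound 4 gives only a limit in this assay: the limit of > 100000 nM in this assay, at which 2 of the 4 values shown sit. On these data alone, what acetyl in place of hydrogen does to activity in this assay stays open.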